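Compound 3 to compound 4: one added bromo

The source may hold more compounds than are shown below. What is called first, only, known or untested is meant among the compounds shown, and "the series" means these compounds.

Of the compounds shown here, three have been measured so far in a functional assay on A549 cells (Homo sapiens) for cytotoxicity, read by CCK-8 assay, with a stated time of 72 h; a lower number here means a stronger inhibitor, a higher number a weaker inhibitor. Within the data shown here, compound 1 `COC(=O)CC1CNC(=O)c2cc(Br)c(Br)n21` gives 82000 nM, the only numerical value. Compound 2 `COC(=O)Cc1c[nH]c(=O)c2cccn12` reads > 200000 nM, which is a limit of the assay. Compound 3 `COC(=O)CC1CNC(=O)c2cccn21` reads > 200000 nM, also a limit of the assay. Compound 3 therefore has no number of its own and stands at the limit of > 200000 nM in this assay, at which 2 of the 3 values shown sit.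

Compound 4 `COC(=O)CC1CNC(=O)c2ccc(Br)n21` differs from compound 3 in one place: bromo in place of hydrogen on an aromatic carbon. The bromo replaces hydrogen on an aromatic carbon, next to the ring nitrogen. Among the measured compounds shown here, no measured pair isolates a single bromo, so the expectation rests on one comparison: compound 1, which also carries bromo, reaches 82000 nM. A modest move towards stronger inhibition in this assay is expected, and the reading may well remain a limit. The estimated change is an at least 1.3-fold lower number from compound 3 to compound 4 (0.12 log units; that floor lies within the scatter). For compound 4 the expected value is 150000 nM, within an estimated range of 80000 nM to 280000 nM.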

Compound 4, half-maximal inhibitory concentration: 65000 nM
For compound 4 the middle estimate is 2.3-fold (0.36 log units) above the measured one; the whole stated range lies above it.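

In this assay a single bromo on an aromatic carbon, next to the ring nitrogen, gives an at least 3.0-fold lower number from compound 3 to compound 4 (0.48 log units; beyond the scatter), so this one position is enough to bring a reading off the limit. Compound 3 reads > 200000 nM, a limit of the assay, so this step is a bound and not a size, and that limit is common in this small set: the limit of > 200000 nM in this assay, at which 2 of the 4 values shown sit. The further bromo of compound 1 cannot be told apart in this assay, with a 1.3-fold lower number from compound 1 to compound 4 (0.10 log units; within the scatter), so it is not needed for a reading of this order.

From the compounds shown here alone, whether the effect is specific to bromo stays open, since chloro, methyl or an amine at the same carbon would be needed to show it. The compounds shown also leave open how the methyl ester contributes, which a carboxylic acid or an amide in its place would test.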